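This account rests on a few compounds, and the source may have more. Where it says the series, first, only, none or still open, it means among the compounds named here.

In a functional assay on MDA-MB-468 cells (Homo sapiens) for antiproliferative activity (on this read-out higher numbers stand for weaker inhibition of growth and lower numbers for stronger inhibition of growth), compound 1 `COc1ccc(-c2nc3ccccc3s2)cc1OC` gives a value of (530 nM), compound 2 `COc1ccc(-c2nc3cc(F)ccc3s2)cc1C` gives (58 nM) and compound 3 `COc1ccc(-c2nc3cc(F)ccc3s2)cc1F` gives (640 nM). Compound 3 therefore stands level with compound 1 and far above compound 2. Compound 4 `COc1ccc(-c2nc3cc(F)ccc3s2)cc1Br` differs from compound 3 by bromo in place of fluoro on an aromatic carbon, ortho to a methoxy group (bromo in place of fluoro on an aromatic carbon). Within the data shown here, the one measured step at this carbon is a large one, fluoro in place of methyl (an 11-fold higher number from compound 2 to compound 3 (1.04 log units; beyond the scatter)). Among the measured compounds shown here, no measured compound carries bromo, so that step offers only a tentative direction. A moderate fall in the number is expected (a 4.3-fold lower number from compound 3 to compound 4 (0.63 log units; beyond the scatter)). For compound 4 the estimated value is (150 nM), with an expected range from (35 nM) to (600 nM).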

Compound 4, concentration for 50% growth inhibition: 420 nM
The estimate for compound 4 lay 2.8-fold (0.45 log units) below the measured number; measured number inside the range.
By their numbers in this assay, from the lowest: compound 2; then compounds 4, 1 and 3 (each within the scatter of the next).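

In this assay, bromo in place of fluoro at this carbon, ortho to a methoxy group, makes no clear difference (a 1.5-fold lower number from compound 3 to compound 4 (0.18 log units; within the scatter)), so these two halogens cannot be told apart here. Bromo in place of methyl (a 7.2-fold higher number from compound 2 to compound 4 (0.86 log units; beyond the scatter)) shows that the earlier loss on leaving methyl is not confined to fluoro. No measurement at hand explains why methyl differs from these halogens. On these data alone, whether an ethyl group, an amine or a hydroxyl group at this carbon would match methyl remains open.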